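This account rests on a few compounds, and the source may have more. Where it says the series, first, only, none or still open, it means among the compounds named here.

Compound 2 `O=c1ccoc2cc(OCc3cn(Cc4ccc(Cl)cc4Cl)nn3)ccc12` carries the shared core with a 2,4-dichlorobenzyl group on the saturated chain carbon bound to an aromatic nitrogen. In a functional assay on SW480 cells (Homo sapiens) for cytotoxicity, read by MTT assay, with a stated time of 48 h (a lower number here means a stronger inhibitor, a higher number a weaker inhibitor), compound 2 gives > 100000 nM, which is a limit of the assay and not a number. Among the compounds with values here, compound 1 `O=c1ccoc2cc(OCc3cn(Cc4cccc(Br)c4)nn3)ccc12`, the only other measured member of the series, differs from compound 2 by a 3-bromophenyl in place of the 2,4-dichlorophenyl at the same place. In this assay compound 1 gives > 100000 nM, also a limit and not a number. The step that the two limits leave unreadable from compound 1 to compound 2 is therefore unreadable, and both measured values sit at the limit of > 100000 nM in this assay, at which 2 of the 2 values shown sit.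

Compound 3 `COc1ccc(Cn2cc(COc3ccc4c(=O)ccoc4c3)nn2)cc1` has not yet been measured in this assay. From compound 2 it differs by 4-methoxyphenyl in place of 2,4-dichlorophenyl on a saturated chain carbon bound to an aromatic nitrogen. Within the data shown here, the only measured step, from compound 1 to compound 2, bears on this position but has no readable size, so no sizeable shift in either direction is expected. The step of a number no higher from compound 2 to compound 3 (the limit leaves the size open) is expected to stay within the scatter. Compound 3 is estimated at 100000 nM, ranging from 30000 nM to 500000 nM, and most likely reported again as a limit.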

Compound 3, half-maximal inhibitory concentration: 20400 nM
Beside the measured number, compound 3's estimate is 4.9-fold (0.69 log units) above it; the measured number lies below the stated range.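

Working from this assay, this position is the first in the series to give a number rather than a limit, with compound 3 at 20400 nM. From the compounds shown here alone, the change to 4-methoxyphenyl on the saturated chain carbon bound to an aromatic nitrogen gives an at least 4.9-fold lower number from compound 2 to compound 3 (0.69 log units; beyond the scatter), and the same group gives an at least 4.9-fold lower number from compound 1 to compound 3 (0.69 log units; beyond the scatter), so the group at this place can move the read-out beyond the scatter, and the true size of both steps stays open. The step between the two halogen-bearing compounds cannot be read, and compound 1 and compound 2 both remain at a limit and not at a number: the limit of > 100000 nM in this assay, at which 2 of the 3 values shown sit.

With a single numbered compound, the shift cannot be divided between the loss of chlorine or bromine and the arrival of the methoxy group with its hydrogen-bond acceptor. Going by these compounds, an unsubstituted phenyl, or a hydroxyl or longer alkoxy chain in place of the methoxy, would be needed to separate these, and whether any group at this place goes further than compound 3 remains unknown.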